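Cytotoxicity notes for compounds 1, 2 and 3

This account rests on a few compounds, and the source may have more. Where it says the series, first, only, none or still open, it means among the compounds named here.

Compound 1 `O=[N+]([O-])c1cccc(/N=N/N2CCCC2)c1` has been tested in an ADME assay on MDBK cells (Bos taurus) for cytotoxicity, read by MTT assay, with a stated time of 96 h; on this read-out higher numbers stand for lower toxicity in this test and lower numbers for higher toxicity in this test. In this assay compound 1 gives > 100000 nM, which is a limit of the assay and not a number. Compound 2 `O=[N+]([O-])c1cccc(/N=N/Nc2cccc([N+](=O)[O-])c2)c1` has also been run. In this assay compound 2 gives > 100000 nM, again a limit rather than a number. Within the data shown here, compound 1 therefore stands at the limit of > 100000 nM in this assay, at which 2 of the 2 values shown sit; no numeric value places it anywhere within the set, and no step between measured compounds can be stated. Compound 3 `c1ccc(/N=N/N2CCCC2)cc1` is not yet measured. It differs from compound 1 by hydrogen in place of nitro on an aromatic carbon. Among the measured compounds shown here, no measured step informs this change, and with both known values sitting at the limit, no shift beyond the scatter in this assay is expected in either direction. The estimate for compound 3 in this assay is 100000 nM, within 50000 nM to 200000 nM. The expected step is a number no higher from compound 1 to compound 3 (the limit leaves the size open).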

Compound 3, half-maximal cytotoxic concentration: > 100000 nM
Compound 3: no number, only a limit (the forecaster's own chance of this, stated with the estimate: 85%); the middle value lies on the limit itself.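

No new step can be read between compound 1 and compound 3 in this assay, as both values are limits and not numbers: the limit of > 100000 nM in this assay, at which 3 of the 3 values shown sit.

The compounds shown leave open where any of them reaches a half-maximal cytotoxic concentration, and whether hydrogen in place of nitro shifts it.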